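Swapping bromo for ethoxy on a soluble compound

The compounds below may be only part of what the source reports. "The series", "measured", "known", "first", "only" and "open" are said of these compounds alone.

Compound 1 `CN(C/C=C/c1ccc(Cl)cc1)Cc1ccc2c(c1)CCCC2` gives 1900 ug/mL
Compound 2 `CN(C/C=C/c1ccc(Br)cc1)Cc1ccc2c(c1)OCCC2` gives 16400 ug/mL

In a physicochemical assay for solubility (a lower number here means a less soluble compound, a higher number a more soluble compound), compound 2 (16400 ug/mL) holds the higher of the two numbers, and compound 1 (1900 ug/mL) lies below it by more than the usual scatter. The next compound to be measured, compound 3 `CCOc1ccc(/C=C/CN(C)Cc2ccc3c(c2)OCCC3)cc1`, keeps the rest of compound 2 and makes one change. It carries ethoxy in place of bromo on an aromatic carbon, para to a large group (ethoxy in place of bromo on an aromatic carbon). Within the data shown here, no measured pair shows this swap alone, as compounds 1 and 2 differ in more than one place, so any forecast here is loose. A small downward step a 1.5-fold lower number from compound 2 to compound 3 (0.17 log units; within the scatter) is expected, probably not beyond the scatter. The estimate for compound 3 is 11000 ug/mL (expected range 4000 ug/mL to 30000 ug/mL).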

Compound 3, solubility: 10200 ug/mL
The estimate for compound 3 lay 1.1-fold (0.03 log units) above the measured number, within the range that was stated.
By their numbers in this assay, from the lowest: compound 1; then compounds 3 and 2 (each within the scatter of the next).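

In this assay, among these compounds, ethoxy in place of bromo on an aromatic carbon, para to a large group, gives a 1.6-fold lower number from compound 2 to compound 3 (0.21 log units; within the scatter), and this is the first pair to show that swap alone. At this position, then, a group of 3 heavy atoms carrying 1 hydrogen-bond acceptor can replace a single bromine atom with a difference that stays within the scatter of repeated measurements. No measurement at hand speaks to the reason for this result.

From the compounds shown here alone, whether an amine, a carboxylic acid or a chain longer than ethoxy at this position would also stay within the scatter remains open. Going by these compounds, this pair also speaks only for the core of compound 2, so the effect of the same swap on the core of compound 1 is unknown.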